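The compounds below may be only part of what the source reports. "The series", "measured", "known", "first", "only" and "open" are said of these compounds alone.

Compound 1 `Cc1c(C(=O)c2ccccc2)oc2ccc(NC(=O)c3ccc(F)cc3)cc12`, measured in a functional assay on PC-3 cells (Homo sapiens) for antiproliferative activity, read by MTT assay, with a stated time of 48 h (on this read-out higher numbers stand for weaker inhibition and lower numbers for stronger inhibition), gives 13500 nM.
Compound 2 `Cc1c(C(=O)c2ccccc2)oc2ccc(S(=O)(=O)Nc3ccc(F)cc3)cc12`, measured in the same way, gives 22100 nM.

Compound 2 stands with the higher of the two numbers, which on this read-out means the weaker inhibition of cell growth, but its nearest neighbour, compound 1, lies within the usual scatter of such measurements, so the two compounds cannot be told apart on these data. Compound 3 `CCOC(=O)c1oc2ccc(S(=O)(=O)Nc3ccc(F)cc3)cc2c1C` keeps the rest of compound 2 unchanged and alters only the group attached to the carbonyl carbon: ethoxy in place of phenyl on a carbonyl carbon. For the measured compounds named here, no pair of measured compounds differs in this one place, so there is nothing here to show how such a change moves the number in this assay. With so little to go on, the expectation for compound 3 is a step no larger than the scatter, in no particular direction, and a 1.1-fold higher number from compound 2 to compound 3 (0.05 log units; within the scatter) expresses that. Compound 3 is therefore estimated at 25000 nM in this assay, with a range from 8000 nM to 80000 nM.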

Compound 3, half-maximal inhibitory concentration: 8560 nM
Beside the measured number, compound 3's estimate is 2.9-fold (0.47 log units) above it; the range from low to high includes it.
By their numbers in this assay, from the lowest: compounds 3, 1 and 2 (each within the scatter of the next, the first and the last beyond it).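

In this assay, putting ethoxy in place of phenyl on a carbonyl carbon gives a 2.6-fold lower number from compound 2 to compound 3 (0.41 log units; beyond the scatter), a modest step but the first at this position that stands clear of the usual scatter. It shows that the number responds to what sits on this carbonyl carbon, so this position is not a silent one in the series. It also shows that the six-membered aromatic ring of the benzoyl group is not required for this level of growth inhibition, as the ethoxycarbonyl compound, with no ring there, gives the lower number. Nothing measured here accounts for the step.

As far as these compounds go, whether ethoxy is a particularly good choice or simply one of many acceptable groups remains open, as a single step gives no trend: a methoxy, a longer butoxy chain, an amine-derived amide or the free carboxylic acid on the same carbonyl carbon could each move the number either way. From the compounds shown here alone, it is also open whether the same change would give a similar step on the core of compound 1, which carries an amide where compound 2 carries a sulfonamide.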